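Lengthening the amine substituent from methyl to propyl

This account rests on a few compounds, and the source may have more. Where it says the series, first, only, none or still open, it means among the compounds named here.

Measured compounds:
- compound 1, `CCCN(Cc1c(C(F)(F)F)nc2n(-c3c(C)cc(C)cc3C)c(Cl)cn12)CC1CCC1`: 5.3 nM
- compound 2, `Cc1cc(C)c(-n2c(Cl)cn3c(CN(C)Cc4ccccc4)c(C(F)(F)F)nc23)c(C)c1`: 160 nM

In an assay on cells for displacement of a labelled ligand from corticotropin-releasing factor receptor 1 (Homo sapiens), with a stated time of 100 min (a lower number here means a stronger inhibitor, a higher number a weaker inhibitor), compound 1 gives 5.3 nM. In this assay compound 2 gives 160 nM, the highest of the two numbers; its nearest neighbour is compound 1, and the step of a 30-fold higher number from compound 1 to compound 2 (1.48 log units; beyond the scatter) is large. That step replaces the whole amino group at once, so it does not isolate the contribution of either substituent on the nitrogen.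

Compound 3, `CCCN(Cc1ccccc1)Cc1c(C(F)(F)F)nc2n(-c3c(C)cc(C)cc3C)c(Cl)cn12`, has not yet been measured in this assay. It differs from compound 2 by ethyl in place of hydrogen on a saturated chain carbon bound to an amine nitrogen; cut one bond further out this reads methyl to propyl, so compound 3 carries the propyl of compound 1 together with the benzyl of compound 2. Within the data shown here, only the step from compound 1 to compound 2 bears on this, and it moves partly back toward compound 1. Compound 3 is therefore expected to show a lower number, a 4.6-fold lower number from compound 2 to compound 3 (0.66 log units; beyond the scatter), with an estimate of 35 nM and a range from 9 nM to 130 nM.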

Compound 3, inhibition constant: 170 nM
Compound 3: the middle estimate sits 4.9-fold (0.69 log units) below what was measured; measured number outside the range, above it.
By their numbers in this assay, from the lowest: compound 1; then compounds 2 and 3 (each within the scatter of the next).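

In this assay the move from benzyl(methyl)amino to benzyl(propyl)amino gives a 1.1-fold higher number from compound 2 to compound 3 (0.03 log units; within the scatter) and so brings no measurable gain while the benzyl stays on the nitrogen. The large difference instead appears with a single change, phenyl in place of cyclobutyl on a saturated chain carbon bound to an amine nitrogen, which gives a 32-fold higher number from compound 1 to compound 3 (1.51 log units; beyond the scatter) and separates what the earlier replacement of the whole amino group could not. Nothing at hand explains why either step has the size it has.

The compounds shown leave open what methyl in place of propyl would do with the cyclobutylmethyl group kept on the nitrogen. They also leave open whether a cyclopropyl or cyclohexyl ring in place of cyclobutyl would stay close to compound 1 or fall with compound 3.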